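Changing the Amide Group of Compound 1

A few compounds are considered here, and "the series" means these few. Any claim that something is new, unique, unknown or untested is made for them only; others in the source may bear on it.

Compound 1 `COc1ccc(/C=C/c2cc(OC)cc(OC)c2/C=C/C(=O)N2CCCCC2)cc1`: 9750 nM
Compound 2 `CCCCCCCCNC(=O)/C=C/c1c(/C=C/c2ccc(OC)cc2)cc(OC)cc1OC`: 8060 nM
Compound 3 `C#CCNC(=O)/C=C/c1c(/C=C/c2ccc(OC)cc2)cc(OC)cc1OC`: 8280 nM

Of the compounds shown here, three have been tested in a functional assay on B16-F10 cells (Mus musculus) for inhibition, read by MTT assay, with a stated time of 48 h; a lower number here means a stronger inhibitor, a higher number a weaker inhibitor. They share one core and differ only in the group attached to the carbonyl carbon of the amide. Compound 1 carries piperidin-1-yl there and gives the highest of the three numbers, though its two neighbours lie within the scatter of it: a 1.2-fold lower number from compound 1 to compound 2 (0.08 log units; within the scatter) and a 1.2-fold lower number from compound 1 to compound 3 (0.07 log units; within the scatter). Between the two open-chain amides the step is just as small: a 1.0-fold higher number from compound 2 to compound 3 (0.01 log units; within the scatter). In short, swapping the amide substituent has so far left this assay unmoved.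

Compound 4 `COc1ccc(/C=C/c2cc(OC)cc(OC)c2/C=C/C(=O)N(CC(C)C)CC(C)C)cc1` continues this series. Compared with compound 1, the change is diisobutylamino in place of piperidin-1-yl on a carbonyl carbon. Both steps that bear on it, from compound 1 to compound 2 and from compound 1 to compound 3, also replaced piperidin-1-yl on the carbonyl carbon, and both stayed within the scatter. A step of similar size, that is none beyond the scatter, is therefore expected: a 1.1-fold lower number from compound 1 to compound 4 (0.03 log units; within the scatter). For compound 4 the value in this assay is estimated at 9000 nM, with a likely range from 4000 nM to 20000 nM.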

Compound 4, half-maximal inhibitory concentration: 4850 nM
Compound 4: middle estimate off by 1.9-fold (0.27 log units), on the high side; the measured number falls inside the stated range.
By their numbers in this assay, from the lowest: compounds 4, 2, 3 and 1 (each within the scatter of the next).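

Within the data shown here, with diisobutylamino on the carbonyl carbon, the amide nitrogen carries two branched chains and no ring, a kind of group the earlier compounds did not include, and in this assay this replacement of piperidin-1-yl gives the largest step seen at this position so far (a 2.0-fold lower number from compound 1 to compound 4 (0.30 log units; within the scatter)). Compound 4 also lacks the amide hydrogen that the octylamino and propargylamino amides keep, yet the steps to it remain small (a 1.7-fold lower number from compound 3 to compound 4 (0.23 log units; within the scatter); a 1.7-fold lower number from compound 2 to compound 4 (0.22 log units; within the scatter)), so no effect of having or lacking that hydrogen can be read from these numbers. Across piperidin-1-yl, octylamino, propargylamino and diisobutylamino, then, a ring, a long chain, a short alkyne-bearing chain and two branched chains have all been placed here without any step going beyond the scatter. Nothing shown here offers an explanation for these small differences. Still open, as far as these compounds go, is whether a morpholin-4-yl or piperazin-1-yl ring on the carbonyl carbon would give a step beyond the scatter. From the compounds shown here alone, a chain ending in an amine or a carboxylic acid remains an equally open case.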